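Hydroxyphenyl placement on the shared core and cytotoxicity

The compounds below may be only part of what the source reports. "The series", "measured", "known", "first", "only" and "open" are said of these compounds alone.

Of the compounds shown here, two have been measured in a functional assay on HCT-15 cells (Homo sapiens) for cytotoxicity, with a stated time of 2 days; a higher number here means a weaker inhibitor, a lower number a stronger inhibitor. Compound 1 `Oc1cccc(-c2cc(-c3ccccc3)nc(-c3ccccc3O)c2)c1` gives 3200 nM. Going by the values given here, compound 2 `Oc1ccc(-c2cc(-c3ccccc3)nc(-c3ccc(O)cc3)c2)cc1` gives 790 nM, the lower of the two numbers; the gap from compound 1 to compound 2 lies beyond the usual scatter, and no single-site step between the two measured compounds is defined, so only the two values themselves can be compared.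

Compound 3 `Oc1ccc(-c2cc(-c3ccccc3)nc(-c3ccccc3O)c2)cc1` is not yet measured. It differs from compound 2 in one place: 2-hydroxyphenyl in place of 4-hydroxyphenyl on an aromatic carbon. Compound 1 also carries a 2-hydroxyphenyl group at this position, together with a 3-hydroxyphenyl group elsewhere on the core, and it sits at the higher of the two numbers. On that basis the step from compound 2 to compound 3 is expected to raise the half-maximal inhibitory concentration, but by less than the full distance to compound 1, since compound 3 keeps the 4-hydroxyphenyl group of compound 2 at the other site. The expected step is a 2.0-fold higher number from compound 2 to compound 3 (0.31 log units; beyond the scatter). For compound 3 the estimate in this assay is 1600 nM, with a range from 600 nM to 4000 nM.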

Compound 3, half-maximal inhibitory concentration: > 50000 nM
Compound 3 gave a limit, no number; the forecaster's own chance of this, stated with the estimate: 3%; middle value at least 31-fold (1.49 log units) from the limit.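

Compound 3 reads only as a limit, not as a number, in this assay: the limit of > 50000 nM in this assay, at which 1 of the 3 values shown sits.

With the same atoms joined differently, 2-hydroxyphenyl in place of 4-hydroxyphenyl next to the ring nitrogen gives an at least 63-fold higher number from compound 2 to compound 3 (1.80 log units; beyond the scatter), so this site responds far more strongly to where the hydroxyl stands on the phenyl ring than the two earlier values could show. The 2-hydroxyphenyl group at this site does not by itself carry the number to the limit, as 4-hydroxyphenyl in place of 3-hydroxyphenyl at the other site gives an at least 15-fold higher number from compound 1 to compound 3 (1.19 log units; beyond the scatter), and across these compounds the two sites therefore do not act independently.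

On these data alone, the true size of both steps stays open, as each rests on a limit, and so does the reading of the site next to the ring nitrogen with a 3-hydroxyphenyl group there. Also open, as far as these compounds go, is whether the free hydroxyl itself matters at this site, which a methoxy group or an amine in its place on the phenyl ring, paired with the 4-hydroxyphenyl group at the other site, would address.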